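The source may report more compounds than this note shows. Statements on the series, on what has been measured and on what is new or still open speak of the compounds shown alone.

For the measured compounds named here, compound 1 (`CCOC(=O)C1=Cc2ccccc2OC1(OCc1cn(CC(=O)NC2CCCCC2)nn1)C(F)(F)F`) is the one member of this small set with a definite number: in a functional assay on A549 cells (Homo sapiens) for inhibition, read by MTT assay, with a stated time of 24 h (on this read-out lower numbers stand for stronger inhibition and higher numbers for weaker inhibition), compound 1 gives 9900 nM. Two companions share its core but carry other groups. For compound 2 (`CCOC(=O)C1=Cc2ccccc2OC1(OCc1cc(-c2ccc(Br)cc2)no1)C(F)(F)F`) the assay reports only a limit rather than a number, > 150000 nM. For compound 3 (`O=C(O)C1=Cc2ccccc2OC1(OCc1cc(-c2ccc(F)cc2F)no1)C(F)(F)F`) the result is likewise a limit, > 150000 nM. Compound 1 therefore stands alone as the measured value, the other two results resting at the limit of > 150000 nM in this assay, at which 2 of the 3 values shown sit.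

Compound 4 (`CCOC(=O)C1=Cc2ccccc2OC1(OCc1cn(CC(=O)Nc2ccc(I)cc2Cl)nn1)C(F)(F)F`) has not yet been measured. It differs from compound 1 in one place: 2-chloro-4-iodophenyl in place of cyclohexyl on an amide-type nitrogen. Going by the values given here, no pair of measured compounds differs by a change of this kind, so the size of the step cannot be read from the data, and no effect is attributed to the entering group. The expectation is a small step in either direction, not beyond the scatter. Compound 4 is accordingly estimated at 8000 nM, with a likely range from 2000 nM to 40000 nM. The expected step is a 1.2-fold lower number from compound 1 to compound 4 (0.09 log units; within the scatter).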

Compound 4, half-maximal inhibitory concentration: 22300 nM
Estimate against measurement, compound 4: 2.8-fold (0.45 log units) below, and the stated range covers the measured number.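

The amide nitrogen now has its first measured change. In this assay the non-aromatic cyclohexyl gives way to the aromatic 2-chloro-4-iodophenyl with a 2.3-fold higher number from compound 1 to compound 4 (0.35 log units; beyond the scatter) and so this position does respond to the group placed on it, modestly and towards weaker inhibition. Compound 4 still gives a definite number, as compound 1 does, and does not join the results that rest at a limit: the limit of > 150000 nM in this assay, at which 2 of the 4 values shown sit.

This single swap changes the ring type and adds chlorine and iodine together, so their separate contributions cannot be told apart, and nothing shown explains the step. Going by these compounds, it remains open whether a plain phenyl without either halogen would behave like compound 1 or compound 4, and how an amine or a longer chain on this amide nitrogen would compare.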